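The compounds below may be only part of what the source reports. "The series", "measured", "known", "first", "only" and "open" are said of these compounds alone.

Of the compounds shown here, three built on a shared core have been tested in a functional assay on HL-60 cells (Homo sapiens) for antiproliferative activity, read by sulforhodamine B assay, with a stated time of 72 h; a lower number here means a stronger inhibitor, a higher number a weaker inhibitor. Compound 1 `Cc1ccc(C(/C=C/c2ccc(F)cc2)=N\Nc2nncc3ccccc23)cc1` gives 8.6 nM. Compound 2 `O=C1CS/C(=N/Nc2nncc3ccccc23)N1c1ccccc1` gives 3 nM. Compound 3 `NC(=S)NNc1nncc2ccccc12` gives 94 nM, the highest number of the three, so it is the weakest inhibitor of this set, and its gaps to compound 1 and to compound 2 both lie beyond the scatter of repeated measurements.

The compound to be measured next, compound 4 `S=C(NNc1nncc2ccccc12)Nc1ccccc1`, differs from compound 3 in a single place: phenyl in place of hydrogen on an amide-type nitrogen. For the measured compounds named here, no pair of measured compounds differs by exactly this change, so there is no directly comparable step. What the numbers do show is that compound 1 and compound 2, which carry larger groups on the shared core than compound 3, both give lower numbers in this assay. On that basis a modest decrease is expected for compound 4, and the change is estimated to give a step of a 3.1-fold lower number from compound 3 to compound 4 (0.50 log units; beyond the scatter). Compound 4 is therefore estimated at 30 nM, within a range from 8 nM to 120 nM.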

Compound 4, half-maximal inhibitory concentration: 95 nM
Estimate against measurement, compound 4: 3.2-fold (0.50 log units) below; measured number inside the range.
By their numbers in this assay, from the lowest: compound 2; then compound 1; then compounds 3 and 4 (each within the scatter of the next).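

Putting phenyl in place of hydrogen on the amide-type nitrogen gives a 1.0-fold higher number from compound 3 to compound 4 (0.00 log units; within the scatter) in this assay. For the compounds shown here, this is the first direct reading at this position, and it shows that the added aromatic ring leaves the two compounds indistinguishable in this test, even though six heavy atoms enter at a nitrogen whose other neighbour is the thiocarbonyl carbon. No measurement shown here offers an explanation for this result.

A single pair cannot show whether this position gives the same result with every group, so a methyl, a benzyl or a longer alkyl chain could still give a different number. The same question stands for a phenyl ring that carries a methoxy group, an amine or a carboxylic acid.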